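The compounds below may be only part of what the source reports. "The series", "measured", "known", "first", "only" and "open" are said of these compounds alone.

Measured compounds in a functional assay on NCI-H460 cells (Homo sapiens) for antiproliferative activity, read by sulforhodamine B assay, with a stated time of 72 h; a higher number here means a weaker inhibitor, a lower number a stronger inhibitor:
compound 1, `CN(CCNCc1cn(-c2ccc(Cl)cc2)nn1)CCNc1ccnc2cc(Cl)ccc12`, gives 14000 nM.
compound 2, `CN(CCNCc1cn(Cc2ccccc2)nn1)CCNc1ccnc2cc(Cl)ccc12`, gives 32000 nM.
compound 3, `CN(CCNCc1cn(CCCO)nn1)CCNc1ccnc2cc(Cl)ccc12`, gives > 200000 nM, which is a limit of this assay, not a number.

Compound 3 thus stands at the limit of > 200000 nM in this assay, at which 1 of the 3 values shown sits, the weakest point of the three. Compound 4, `CN(CCNCc1cn(-c2nc3ccccc3[nH]2)nn1)CCNc1ccnc2cc(Cl)ccc12`, differs from compound 3 by 1H-benzimidazol-2-yl in place of 3-hydroxypropyl on an aromatic nitrogen. The measured steps that bear on this are an at least 14-fold higher number from compound 1 to compound 3 (1.15 log units; beyond the scatter) and an at least 6.2-fold higher number from compound 2 to compound 3 (0.79 log units; beyond the scatter), both showing that an aryl or benzyl group on that nitrogen gives a lower number than the 3-hydroxypropyl group; within those, a 2.3-fold higher number from compound 1 to compound 2 (0.36 log units; beyond the scatter) favours the aryl. A return to an aryl group is therefore expected to bring a large step down in this assay, an at least 10-fold lower number from compound 3 to compound 4 (1.00 log units; beyond the scatter). Compound 4 is estimated at 20000 nM, in the range 6000 nM to 80000 nM.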

Compound 4, half-maximal inhibitory concentration: 33000 nM
Estimate against measurement, compound 4: 1.7-fold (0.22 log units) below, and the stated range covers the measured number.
By their numbers in this assay, from the lowest: compound 1; then compounds 2 and 4 (each within the scatter of the next). At a limit, above all of these: compound 3.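

In this assay, 1H-benzimidazol-2-yl on the aromatic nitrogen gives a clear gain over 3-hydroxypropyl (an at least 6.0-fold lower number from compound 3 to compound 4 (0.78 log units; beyond the scatter)), so a third ring-bearing group sits well clear of the chain. Compound 3 gives a limit of the assay, not a number: the limit of > 200000 nM in this assay, at which 1 of the 4 values shown sits. The larger group brings nothing over benzyl (a 1.0-fold higher number from compound 2 to compound 4 (0.01 log units; within the scatter)) and falls short of 4-chlorophenyl (a 2.4-fold higher number from compound 1 to compound 4 (0.37 log units; beyond the scatter)).

Open, going by these compounds, is whether a plain propyl chain would sit with compound 3 or with the ring-bearing compounds. On these data alone, a terminal amine or carboxylic acid on the chain is equally open.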